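Swapping a Phenyl for Isopropyl: Expected Solubility

The source may report more compounds than this note shows. Statements on the series, on what has been measured and on what is new or still open speak of the compounds shown alone.

Compound 1 `COc1ccccc1C(=O)NC(=O)Nc1ccc(-c2ccccc2)c(C(F)(F)F)c1`: 23 ug/mL
Compound 2 `COc1ccccc1C(=O)NC(=O)Nc1ccc(-c2ccccn2)c(C(F)(F)F)c1`: 8.5 ug/mL

Going by the values given here, in a physicochemical assay for solubility, in simulated intestinal fluid (a lower number here means a less soluble compound, a higher number a more soluble compound), compound 1 gives 23 ug/mL, the higher of the two numbers measured so far. Compound 2 gives 8.5 ug/mL, and the step of a 2.7-fold lower number from compound 1 to compound 2 (0.43 log units; beyond the scatter). Compound 3 `COc1ccccc1C(=O)NC(=O)Nc1ccc(C(C)C)c(C(F)(F)F)c1` differs from compound 1 in one respect: isopropyl in place of phenyl on an aromatic carbon. Among the compounds with values here, no measured step makes this same change; the one step known swaps the same phenyl for a different ring and was modest. A step of comparable size, a 1.5-fold higher number from compound 1 to compound 3 (0.18 log units; within the scatter), is therefore expected, though it may stay within the scatter. Compound 3 is estimated at 35 ug/mL, with a range from 12 ug/mL to 100 ug/mL.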

Compound 3, solubility: 6.9 ug/mL
Compound 3: the middle estimate sits 5.1-fold (0.71 log units) above what was measured, outside the stated range (below it).
By their numbers in this assay, from the lowest: compounds 3 and 2 (each within the scatter of the next); then compound 1.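

In this assay, a group without a ring at this position does not raise the number, as there is a 3.3-fold lower number from compound 1 to compound 3 (0.52 log units; beyond the scatter) once isopropyl replaces phenyl. Isopropyl and pyridin-2-yl cannot be told apart, with a 1.2-fold lower number from compound 2 to compound 3 (0.09 log units; within the scatter), so both replacements of phenyl end up at a similar level even though only one keeps an aromatic ring. No measurement at hand explains why compound 1 stands apart from the other two.

On these data alone, whether an amine, a carboxylic acid or a longer chain at this position would give a number above that of compound 1 remains open. So does whether isopropyl in place of phenyl would have the same result on a different core.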